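A longer diethylamino chain on compound 3

A few compounds are considered here, and "the series" means these few. Any claim that something is new, unique, unknown or untested is made for them only; others in the source may bear on it.

Values in a functional assay on A549 cells (Homo sapiens) for antiproliferative activity, read by MTT assay, with a stated time of 48 h (a lower number here means a stronger inhibitor, a higher number a weaker inhibitor), follow
compound 1 `CN(C)CCn1c(N)c(-c2nc3ccccc3[nH]2)c2nc(C#N)c(C#N)nc21` gives > 50000 nM (a limit)
compound 2 `CN1CCN(CCn2c(N)c(-c3nc4ccccc4[nH]3)c3nc(C#N)c(C#N)nc32)CC1` gives 40500 nM
compound 3 `CN(C)CCn1c(N)c(-c2nc3ccccc3n2C)c2nc(C#N)c(C#N)nc21` gives > 50000 nM (a limit)

Compound 3 gives only a limit (> 50000 nM) and no number. Its standing is the limit of > 50000 nM in this assay, at which 2 of the 3 values shown sit, and no more. Compound 4 `CCN(CC)CCCCn1c(N)c(-c2nc3ccccc3n2C)c2nc(C#N)c(C#N)nc21` carries 2-(diethylamino)ethyl in place of dimethylamino on a saturated chain carbon, two bonds along the chain from an aromatic nitrogen. Among the compounds with values here, two measured steps bear on this. Within the data shown here, changing the amine gave an at least 1.2-fold lower number from compound 1 to compound 2 (0.09 log units; that floor lies within the scatter) and adding the methyl gave a step that the two limits leave unreadable from compound 1 to compound 3 as the only other guide. Neither shows a firm size, so only a small move to a lower number is expected (an at least 1.4-fold lower number from compound 3 to compound 4 (0.15 log units; that floor lies within the scatter)), and another limit would be no surprise. Compound 4 is estimated at 35000 nM (expected range 12000 nM to 70000 nM).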

Compound 4, half-maximal inhibitory concentration: 1720 nM
Compound 4: middle estimate off by 20-fold (1.31 log units), on the high side; the measured number lies below the stated range.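

In this assay, within the data shown here, replacing dimethylamino with 2-(diethylamino)ethyl on this saturated chain carbon gives an at least 29-fold lower number from compound 3 to compound 4 (1.46 log units; beyond the scatter), the first step here that is both readable and beyond the scatter. Changes to the chain on this aromatic nitrogen can therefore have a large effect, which the earlier amine change did not show. Compound 3 is a limit, and this step is therefore only a floor: the limit of > 50000 nM in this assay, at which 2 of the 4 values shown sit.

Chain length and the amine change together in this step, and the compounds shown do not separate them. A 4-(dimethylamino)butyl chain would be needed to tell the two apart.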